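The source may report more compounds than this note shows. Statements on the series, on what has been measured and on what is new or still open speak of the compounds shown alone.

In a functional assay on M21 cells (Homo sapiens) for antiproliferative activity, read by sulforhodamine B assay, with a stated time of 48 h (a lower number here means a stronger inhibitor, a higher number a weaker inhibitor), compound 1 `CCCN1CCN(c2ccc(S(=O)(=O)Oc3ccccc3CC)cc2)C1=O` gives > 50000 nM, which is a limit. Compound 2 `CCCN1CCN(c2ccc(S(=O)(=O)Oc3ccccc3OC)cc2)C1=O` gives > 100000 nM, which is also a limit. For the measured compounds named here, compound 3 `CCCN1CCN(c2ccc(S(=O)(=O)Oc3cc(Cl)c(Cl)cc3Cl)cc2)C1=O` gives 15000 nM, the only value of the three that is a number. The two limits leave a step that the two limits leave unreadable from compound 1 to compound 2. The readable steps are an at least 3.3-fold lower number from compound 1 to compound 3 (0.52 log units; beyond the scatter) and an at least 6.6-fold lower number from compound 2 to compound 3 (0.82 log units; beyond the scatter), and both bring in the 2,4,5-trichlorophenyl group.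

Compound 4 `CCCN1CCN(c2ccc(S(=O)(=O)Oc3c(Cl)cc(Cl)cc3Cl)cc2)C1=O` has the same atoms as compound 3, joined differently: 2,4,6-trichlorophenyl in place of 2,4,5-trichlorophenyl on an oxygen. It carries 2,4,6-trichlorophenyl in place of 2,4,5-trichlorophenyl on an oxygen. The two readable steps bear on this change only loosely, since neither compares two trichlorophenyl groups. They show that the group on this oxygen can matter, but they give no direction for the new change. The expected result is no change at the digits printed from compound 3 to compound 4 (within the scatter), with no step beyond the scatter anticipated in either direction. For compound 4, the estimated value in this assay is 15000 nM, with an expected range from 5000 nM to 45000 nM.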

Compound 4, half-maximal inhibitory concentration: 56000 nM
The estimate for compound 4 lay 3.7-fold (0.57 log units) below the measured number; measured number above the stated range.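

Going from the 2,4,5-trichlorophenyl to the 2,4,6-trichlorophenyl group on this oxygen, with the same atoms joined differently, gives a 3.7-fold higher number from compound 3 to compound 4 (0.57 log units; beyond the scatter) in this assay, so how the chlorines are arranged matters here, and not only that they are present. The 2,4,6-trichlorophenyl group also holds no clear lead over 2-methoxyphenyl, with an at least 1.7-fold lower number from compound 2 to compound 4 (0.25 log units; that floor lies within the scatter) in this assay, while the step involving the 2-ethylphenyl group cannot be read. Nothing shown here explains why the arrangement of the chlorines shifts the number.

The compounds shown leave open whether bromine or trifluoromethyl in place of these chlorines would retain the number of compound 3. They also leave open how an amine or a carboxylic acid on this ring, or a longer chain in place of the propyl group, would behave.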